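Methoxyphenyl Replaces Dichlorophenyl on the Exocyclic Chain Carbon

The compounds below may be only part of what the source reports. "The series", "measured", "known", "first", "only" and "open" are said of these compounds alone.

Compound 1 `O=C1/C(=C\c2c(Cl)cccc2Cl)c2ccccc2N1c1c(Cl)cccc1Cl` was examined in a functional assay on MCF7 cells (Homo sapiens) for cytotoxicity, read by MTT assay, with a stated time of 72 h; a lower number here means that less compound is needed, a higher number that more compound is needed for the effect. In this assay compound 1 gives > 100 ug/mL, which is a limit of the assay rather than a measured number. Compound 2 `Cc1ccc2nc(Cl)c(/C=C3\C(=O)N(c4c(Cl)cccc4Cl)c4ccccc43)cc2c1C` shares the same core and carries a different aryl group on the chain carbon. In this assay compound 2 gives > 100 ug/mL, again a limit and not a number. Going by the values given here, both results sit at the limit of > 100 ug/mL in this assay, at which 2 of the 2 values shown sit, so the two values show only that neither compound reached a half-maximal effect, and no step between measured compounds is available to calibrate any change.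

The unmeasured compound 3 `COc1ccc(/C=C2\C(=O)N(c3c(Cl)cccc3Cl)c3ccccc32)cc1` differs from compound 1 by 4-methoxyphenyl in place of 2,6-dichlorophenyl on a double-bonded chain carbon bound to a double-bonded ring carbon. Among the compounds with values here, no measured pair spans a change of this kind, so the size of the step cannot be read from the data. The expected step of an at least 1.2-fold lower number from compound 1 to compound 3 (0.09 log units; that floor lies within the scatter) is therefore judged to be small or none beyond the scatter. Compound 3 is estimated to give 80 ug/mL, with a range from 30 ug/mL to 200 ug/mL. This expectation rests on compound 1, which gives > 100 ug/mL.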

Compound 3, concentration for half-maximal effect: > 100 ug/mL
Compound 3 ended at the assay's limit (the forecaster's own chance of this, stated with the estimate: 60%); middle value at least 1.2-fold (0.09 log units) from the limit.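

Compound 3, like compound 1, ended at a limit in this assay and not at a number, so no step between the two can be read: the limit of > 100 ug/mL in this assay, at which 3 of the 3 values shown sit.

The compounds shown leave open whether any aryl group on the chain carbon of the shared core can bring a half-maximal effect in this assay, and how 4-methoxyphenyl and 2,6-dichlorophenyl truly compare.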